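Swapping One Ring Group in a Permeability Series

This account rests on a few compounds, and the source may have more. Where it says the series, first, only, none or still open, it means among the compounds named here.

For the measured compounds named here, in an ADME assay for permeability, using PAMPA (a higher number here means that the compound crosses the layer faster, a lower number that the compound crosses the layer more slowly), compound 2 `COc1ccc(Cl)c(-c2noc(C(C)C)c2COc2ccc(-c3ccc4c(C(=O)O)cn(C)c4c3)c(C)c2)n1` gives 0.7 10^-6 cm/s, the only number so far. Going by the values given here, compound 1 `Cc1cc(OCc2c(-c3c(Cl)ccc(=O)n3C)noc2C(C)C)ccc1-c1ccc2c(C(=O)O)cn(C)c2c1` shows "not active" (no number reported) in this assay, with no number reported, so no measured step is available as a guide. Compound 3 `Cc1cc(OCc2c(-c3[nH]c(=O)ccc3Cl)noc2C(C)C)ccc1-c1ccc2c(C(=O)O)cn(C)c2c1` differs from compound 2 in one place, on an aromatic carbon of a five-membered aromatic ring with 1 nitrogen and 1 oxygen, where the 3-chloro-6-methoxypyridin-2-yl group is replaced: a group of 8 heavy atoms (5 carbon, 1 nitrogen, 1 oxygen, 1 chlorine; one six-membered aromatic ring with 1 hetero atom) in place of a group of 9 heavy atoms (6 carbon, 1 nitrogen, 1 oxygen, 1 chlorine; one six-membered aromatic ring with 1 hetero atom), on an aromatic carbon. The evidence for direction is thin. It rests on compound 1, which gives "not active" (no number reported) and, like compound 3, has a double bond outside aromatic rings in this group. The estimated change, a 2.3-fold lower number from compound 2 to compound 3 (0.37 log units; beyond the scatter), is a modest fall, slightly beyond the usual scatter. For compound 3 the expected value is 0.3 10^-6 cm/s, with an estimated range of 0.1 10^-6 cm/s to 0.8 10^-6 cm/s.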

Compound 3, apparent permeability: "not active" (no number reported)
For compound 3 the study gives words and no number; the estimate stays without a comparison.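

For the compounds shown here, compound 3, like compound 1, is reported in this assay in words without a number, so no step from compound 2 to either can be read. No evidence here bears on this result. The compounds shown leave open how far, and in which direction, the swapped group moves the number.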